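Amino on the fused core and its removal

The source may hold more compounds than are shown below. What is called first, only, known or untested is meant among the compounds shown, and "the series" means these compounds.

Compound 3 `Nc1n[nH]c2cc(-c3ccc(=O)n(Cc4cccc(F)c4)c3)ccc12` carries the lowest of the two numbers shown in an assay for inhibition of MAP kinase-interacting serine/threonine-protein kinase 1 (Homo sapiens), read by luminescence and ADP-Glo, with a stated time of 2 h; a lower number here means a stronger inhibitor, a higher number a weaker inhibitor: compound 3 gives 19 nM. The nearest measured number belongs to compound 1 `NC(=O)c1cccc(Cn2cc(-c3ccc4cn[nH]c4c3)ccc2=O)c1`, which in this assay gives 388 nM, a gap beyond the scatter. Compound 2 `O=C(N1CCOCC1)n1cc(-c2ccc3cn[nH]c3c2)ccc1=O` sits at the limit of this assay, > 2000 nM, and not at a number; the limit line the limit of > 2000 nM in this assay, at which 1 of the 3 values shown sits, records that one of the three values rests there.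

Compound 4 `O=c1ccc(-c2ccc3cn[nH]c3c2)cn1Cc1cccc(F)c1` is compound 3 with hydrogen in place of amino on an aromatic carbon. Going by the values given here, no step between measured compounds isolates this change, so the expectation rests on the two numbers alone: compound 1, which also lacks the amino, gives 388 nM, while compound 3 with the amino gives 19 nM. The step is therefore expected to go toward a higher number, beyond the scatter, and compound 4 is estimated at 200 nM, within 60 nM to 800 nM. That estimate means an expected step of an 11-fold higher number from compound 3 to compound 4 (1.02 log units; beyond the scatter).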

Compound 4, half-maximal inhibitory concentration: 74 nM
Beside the measured number, compound 4's estimate is 2.7-fold (0.43 log units) above it, and the stated range covers the measured number.
By their numbers in this assay, from the lowest: compound 3; then compound 4; then compound 1. At a limit, above all of these: compound 2.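

Taken alone, hydrogen in place of amino on this aromatic carbon of the five-membered ring gives a 3.9-fold higher number from compound 3 to compound 4 (0.59 log units; beyond the scatter) in this assay and so isolates what the earlier compounds could not. With the amino absent, fluoro in place of carbamoyl on an aromatic carbon gives a 5.2-fold lower number from compound 1 to compound 4 (0.72 log units; beyond the scatter) as a separate step beyond the scatter, so the gap between compound 3 and compound 1 spans changes in two places. Compound 2 stands at a limit of the assay, which makes an at least 27-fold lower number from compound 2 to compound 4 (1.43 log units; beyond the scatter) a bound for 3-fluorobenzyl in place of (morpholin-4-yl)carbonyl on an aromatic nitrogen and not an exact step.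

Nothing shown here accounts for any of these steps. Open questions are whether methylamino, acetamido or hydroxyl on this carbon would match amino, and whether amino and carbamoyl would combine on one compound.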